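This account rests on a few compounds, and the source may have more. Where it says the series, first, only, none or still open, it means among the compounds named here.

Compound 2 `N#Cc1ccc(-c2cnc3[nH]cc(-c4nnc(-c5ccc(Cl)cc5)o4)c(=O)c3c2)cc1` holds the higher of the two numbers seen so far in a functional assay on HCT-116 cells (Homo sapiens) for inhibition, read by MTT assay, with a stated time of 24 h, tested at 5 uM (on this read-out higher numbers stand for more inhibition of growth at the one concentration tested and lower numbers for less inhibition of growth), giving 17.9%; compound 1 `N#Cc1ccc(-c2cnc3[nH]cc(-c4nnc(-c5ccc(F)cc5)o4)c(=O)c3c2)cc1` gives 12.6%, and the step of a number 5.3 percentage points higher from compound 1 to compound 2 (within the scatter) lies within the scatter. Compound 3 `O=c1c(-c2nnc(-c3ccc(Cl)cc3)o2)c[nH]c2ncc(-c3ccccc3)cc12` differs from compound 2 by hydrogen in place of cyano on an aromatic carbon. Within the data shown here, no measured step concerns the cyano group: the single step seen, a number 5.3 percentage points higher from compound 1 to compound 2 (within the scatter), swaps one halogen for another and stays within the scatter, so it offers no guide to this change. The expected step of a number 3.9 percentage points lower from compound 2 to compound 3 (within the scatter) is accordingly none beyond the scatter. Compound 3 is therefore estimated at 14%, within 0% to 30%.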

Compound 3, percent growth inhibition at one concentration: 12.3%
Beside the measured number, compound 3's estimate is 1.7 percentage points above it, and the stated range covers the measured number.
By their numbers in this assay, from the lowest: compounds 3, 1 and 2 (each within the scatter of the next).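

Replacing cyano with hydrogen, the change 4-cyanophenyl to phenyl, gives a number 5.6 percentage points lower from compound 2 to compound 3 (within the scatter) in this assay. This is the first read on this position, and with the chloro compounds the nitrile is not shown to be needed for growth inhibition at the one concentration tested. No measurement on hand bears on the reason for this result.

Still open, going by these compounds, is whether an amine or a carboxylic acid on this aromatic carbon would move the number beyond the scatter. On these data alone, the same change with the fluoro partner of compound 1 also remains open.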